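The source may report more compounds than this note shows. Statements on the series, on what has been measured and on what is new or still open speak of the compounds shown alone.

Working notes on the series. The read-out throughout is a functional assay on CCRF-CEM cells (Homo sapiens) for cytotoxicity, in the absence of a further agent; a higher number here means a weaker inhibitor, a lower number a stronger inhibitor. Compound 1, `Nc1nc(N)c(CCCN(Cc2ccc(NC(CCC(=O)O)C(=O)O)cc2)c2cc(F)c([N+](=O)[O-])cc2[N+](=O)[O-])c(O)n1`, gives 40000 nM in this assay. Compound 2, `COC(=O)c1ccc(CN(CCCc2c(N)nc(N)nc2O)c2cc(F)c([N+](=O)[O-])cc2[N+](=O)[O-])cc1`, gives 2500 nM in this assay. Going by the values given here, the two differ in one place, (methoxycarbonyl in place of (1,3-dicarboxypropyl)amino on an aromatic carbon), and the step of a 16-fold lower number from compound 1 to compound 2 (1.20 log units; beyond the scatter) is the one firm measured change in the set.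

Compound 3, `Nc1nc(N)c(CCCN(Cc2ccc(NC(CCC(=O)O)C(=O)O)cc2)c2ccc([N+](=O)[O-])c(F)c2F)c(O)n1`, carries the same (1,3-dicarboxypropyl)amino as compound 1 on a different core; how the two cores differ is not broken down here. For compound 3 this assay reports only a limit, > 100000 nM, and not a number. The limit in question is the limit of > 100000 nM in this assay, at which 1 of the 3 values shown sits, so the true value of compound 3 is open upward.

Compound 4, `COC(=O)c1ccc(CN(CCCc2c(N)nc(N)nc2O)c2ccc([N+](=O)[O-])c(F)c2F)cc1`, is not yet measured. Among the compounds with values here, it stands to compound 3 as compound 2 stands to compound 1: the change methoxycarbonyl in place of (1,3-dicarboxypropyl)amino on an aromatic carbon is the same change, placed at the same position, as the one measured between compound 1 and compound 2. The expected step of an at least 6.6-fold lower number from compound 3 to compound 4 (0.82 log units; beyond the scatter) is taken from the measured step of a 16-fold lower number from compound 1 to compound 2 (1.20 log units; beyond the scatter), with the caveat that the starting point for compound 3 is a limit rather than a number, which widens the range. On that basis compound 4 is estimated to give 15000 nM in this assay, expected to lie between 3000 nM and 100000 nM.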

Compound 4, half-maximal inhibitory concentration: 41000 nM
The estimate for compound 4 lay 2.7-fold (0.44 log units) below the measured number; measured number inside the range.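

In this assay, methoxycarbonyl in place of (1,3-dicarboxypropyl)amino again gives a lower number on the second core, with an at least 2.4-fold lower number from compound 3 to compound 4 (0.38 log units; beyond the scatter), so the direction of the change carries from the core of compound 1 to the core of compound 3. This is one repeat on two cores, not a general rule for the series, and it fixes no size for the change on the second core, where the step is only a lower bound on the fall; the two steps cannot be ranked against each other: the same change on two cores in this assay, a 16-fold lower number (1.20 log units; beyond the scatter) from compound 1 to compound 2 and an at least 2.4-fold lower number (0.38 log units; beyond the scatter) from compound 3 to compound 4; the limit leaves it open whether they differ. The value of compound 3 is a limit and not a number: the limit of > 100000 nM in this assay, at which 1 of the 4 values shown sits.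

The compounds shown leave open whether the lower numbers go with the arrival of methoxycarbonyl or simply with the departure of (1,3-dicarboxypropyl)amino, and a simple carboxylic acid or an amide on the same aromatic carbon would help to separate the two. Going by these compounds alone, also open is whether the change keeps its direction on a core with a longer chain in place of the one in these compounds.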